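Chloro Added to Compound 3: An Expected Small Shift

The source may report more compounds than this note shows. Statements on the series, on what has been measured and on what is new or still open speak of the compounds shown alone.

In a functional assay on isolated protein for agonist activity at Free fatty acid receptor 1 (Homo sapiens), read by HTRF and inositol phosphate accumulation, with a stated time of 60 min (on this read-out lower numbers stand for an effect already at smaller amounts and higher numbers for an effect only at larger amounts of compound), compound 1 `O=C(O)CCCOc1ccc(-c2cccc(Oc3ccccc3)c2)cc1` gives 6800 nM. Compound 2 `O=C(O)CCCOc1ccc(-c2cc(OC3CC3)ccc2F)cc1` reaches only a limit of the assay, > 9950 nM, and is counted as such (the limit of > 9950 nM in this assay, at which 1 of the 3 values shown sits). Compound 3 `O=C(O)CCc1cc2cc(-c3cccc(OC(F)(F)F)c3)ccc2o1` gives 1390 nM in this assay, the lowest of the two numbers reported; the nearest number, that of compound 1, lies higher by a gap beyond the usual scatter.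

Compound 4 `O=C(O)CCc1cc2cc(-c3cc(OC(F)(F)F)ccc3Cl)ccc2o1` differs from compound 3 in one place: chloro in place of hydrogen on an aromatic carbon. For the measured compounds named here, no pair of measured compounds shows this change, so the size of the step rests only on the pattern among compounds 1, 2 and 3. A step toward a lower number, modest and close to the edge of the scatter, is expected from compound 3 to compound 4, a 1.5-fold lower number from compound 3 to compound 4 (0.19 log units; within the scatter). Compound 4 is therefore estimated at 900 nM in this assay, with a range from 300 nM to 3000 nM.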

Compound 4, half-maximal effective concentration: > 9950 nM
Compound 4 was reported as a limit; the forecaster's own chance of this, stated with the estimate: 5%; at least 11-fold (1.04 log units) between middle value and limit.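

In this assay, chloro in place of hydrogen on an aromatic carbon, ortho to a large group and para to a trifluoromethoxy group, gives an at least 7.1-fold higher number from compound 3 to compound 4 (0.85 log units; beyond the scatter). This is the first single-place change that can be read among the compounds shown, and it shows that adding one chlorine atom at this position is enough to give a step beyond the scatter, in the direction of a higher number. The value of compound 4 is a limit and not a number, and how far the step runs past its printed size cannot be read: the limit of > 9950 nM in this assay, at which 2 of the 4 values shown sit.

From the compounds shown here alone, whether a methyl or a methoxy group at this position would give a similar step remains open. Also open, going by these compounds, is whether chloro on another carbon of the same ring would do the same.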